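The compounds below may be only part of what the source reports. "The series", "measured", "known", "first", "only" and "open" are said of these compounds alone.

Measured so far in a functional assay on the whole organism with Mus musculus as the target; on this read-out lower numbers stand for smaller maximal responses and higher numbers for larger maximal responses:

- Compound 1, `Nc1nc(O)c2c(n1)n(C1OC(CO)[C@@H](O)[C@H]1O)c(=O)n2C/C=C/c1ccccc1`, gives 5%
- Compound 2, `CCCCCCCCCCn1c(=O)n(C2OC(CO)[C@@H](O)[C@H]2O)c2nc(N)nc(O)c21`, gives 0%
- Compound 3, `Nc1nc(O)c2c(n1)n(C1OC(CO)[C@@H](O)[C@H]1O)c(=O)n2Cc1ccc([N+](=O)[O-])cc1`, gives 16%

Compound 3 stands highest of the three in this assay: the step of a number 11 percentage points higher from compound 1 to compound 3 (beyond the scatter) and the step of a number 16 percentage points higher from compound 2 to compound 3 (beyond the scatter) are both beyond the scatter, while the step of a number 5 percentage points lower from compound 1 to compound 2 (within the scatter) is not. The shared core is kept throughout; only the group on the saturated chain carbon bound to an aromatic nitrogen changes.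

Compound 4, `CCCCn1c(=O)n(C2OC(CO)[C@@H](O)[C@H]2O)c2nc(N)nc(O)c21`, has not yet been measured. It differs from compound 3 as follows: propyl in place of 4-nitrophenyl on a saturated chain carbon bound to an aromatic nitrogen. The step that bears on this most directly is a number 16 percentage points higher from compound 2 to compound 3 (beyond the scatter), where a nonyl chain gave way to 4-nitrophenyl and the maximal response rose modestly. Compound 4 goes the other way, from 4-nitrophenyl back to a chain, propyl, though a shorter one than nonyl. A drop of similar size is therefore expected, with the step of a number 12 percentage points lower from compound 3 to compound 4 (beyond the scatter) estimated to bring compound 4 close to where compound 1 and compound 2 sit. Compound 4 is expected to give about 4% in this assay, most likely between 0% and 15%.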

Compound 4, largest response reached (reported as maximal response), in percent of the reference or control that the assay uses: 70%
For compound 4 the middle estimate is 66 percentage points below the measured one; the measured number lies above the stated range.
By their numbers in this assay, from the lowest: compounds 2 and 1 (each within the scatter of the next); then compound 3; then compound 4.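

In this assay, within the data shown here, this position turns out to be far more sensitive than the earlier compounds suggested: a number 54 percentage points higher from compound 3 to compound 4 (beyond the scatter) and a number 65 percentage points higher from compound 1 to compound 4 (beyond the scatter) are both large, whereas the earlier steps were modest or within the scatter. A saturated chain does not by itself give a low number, and its length matters, as a number 70 percentage points higher from compound 2 to compound 4 (beyond the scatter) shows when hexyl is cut from the end of the long chain. No measurement at hand explains this jump.

With only two plain chains shown, it remains open where along the chain length the response falls away, which an ethyl, a hexyl or an octyl chain would help to settle. From the compounds shown here alone, it is also open whether an unsubstituted benzyl, or a butyl chain ending in an amine or a carboxylic acid, would keep the response.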